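Swapping the amide amine on compound 2

The source may hold more compounds than are shown below. What is called first, only, known or untested is meant among the compounds shown, and "the series" means these compounds.

Going by the values given here, in a functional assay on MCF7 cells (Homo sapiens) for antiproliferative activity, read by sulforhodamine B assay, with a stated time of 48 h (a lower number here means a stronger inhibitor, a higher number a weaker inhibitor), compound 2 `CCCCCN(C)C(=O)CCCCCOc1cc(OC)c(OC)c2oc(-c3ccc(OC)cc3)c(O)c(=O)c12` gives 34900 nM, the only true number. Compound 1 `COc1ccc(-c2oc3c(OC)c(OC)cc(OCCCCC(=O)NCc4ccccn4)c3c(=O)c2O)cc1` reads > 40000 nM, which is a limit of the assay. The evidence is thin: the limit of > 40000 nM in this assay, at which 1 of the 2 values shown sits.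

Compound 3 `COc1ccc(-c2oc3c(OC)c(OC)cc(OCCCCCC(=O)NCc4ccccn4)c3c(=O)c2O)cc1` carries ((pyridin-2-yl)methyl)amino in place of methyl(pentyl)amino on a carbonyl carbon. Among the compounds with values here, the one measured step that bears on this exchanges the same two carbamoyl groups: an at least 1.1-fold lower number from compound 1 to compound 2 (0.05 log units; that floor lies within the scatter). Its reverse suggests no change beyond the scatter in this assay, with any drift toward a higher number. The expected step is a 1.1-fold higher number from compound 2 to compound 3 (0.06 log units; within the scatter). Compound 3 is estimated at 40000 nM, with an expected range of 18000 nM to 90000 nM.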

Compound 3, half-maximal inhibitory concentration: > 40000 nM
Compound 3 gave a limit, no number; the forecaster's own chance of this, stated with the estimate: 55%; the middle value sits exactly at the limit.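

In this assay, ((pyridin-2-yl)methyl)amino in place of methyl(pentyl)amino on the carbonyl carbon gives an at least 1.1-fold higher number from compound 2 to compound 3 (0.05 log units; that floor lies within the scatter), so the direct exchange shows no change beyond the scatter. Compound 3 reads > 40000 nM, which is a limit, and the step between compound 1 and compound 3 cannot be read, leaving the added chain carbon without a measurable effect. Most of the series now sits at one ceiling: the limit of > 40000 nM in this assay, at which 2 of the 3 values shown sit.

On these data alone, whether a carboxylic acid at the chain end or a piperidine amide would give a true number remains open. As far as these compounds go, the effect of chain length on a true number also remains open.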